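Dimethylamino Isomer of a Weak Serotonin Receptor Ligand

The source may hold more compounds than are shown below. What is called first, only, known or untested is meant among the compounds shown, and "the series" means these compounds.

Compound 2 `CCNCc1ccc(Cl)c(-c2ccccc2OC)c1` belongs to a small set examined in an assay on isolated protein for binding affinity to 5-hydroxytryptamine receptor 3A (Homo sapiens); a higher number here means a weaker inhibitor, a lower number a stronger inhibitor. In this assay compound 2 gives > 10000 nM, which is a limit of the assay rather than a number. Compound 1 `CCCN(CCC)Cc1ccc(Cl)c(-c2ccccc2OC)c1` is its dipropylamino relative; in this assay compound 1 gives > 10000 nM, also a limit. The step that the two limits leave unreadable from compound 1 to compound 2 therefore cannot be read. Compound 3 `COc1ccccc1-c1cc(CN(C)C)ccc1Cl` differs from compound 2 by dimethylamino in place of ethylamino on a saturated chain carbon bound to an aromatic carbon. For the measured compounds named here, both measured values sit at the limit (the limit of > 10000 nM in this assay, at which 2 of the 2 values shown sit), so no measured step bears readably on this change, and nothing beyond the scatter is expected in either direction. Compound 3 is expected to give 15000 nM, between 3000 nM and 60000 nM. The step that the limit leaves unreadable from compound 2 to compound 3 is estimated to leave it at the limit as well.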

Compound 3, inhibition constant: 1000 nM
Estimate against measurement, compound 3: 15-fold (1.18 log units) above, and the stated range ends above it.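

The change at this place, on a saturated chain carbon bound to an aromatic carbon, gives the first readable response in this assay: an at least 10-fold lower number from compound 2 to compound 3 (1.00 log units; beyond the scatter), and an at least 10-fold lower number from compound 1 to compound 3 (1.00 log units; beyond the scatter). Compounds 2 and 3 have the same atoms, joined differently, so the way these atoms are arranged in the amine group is enough to separate them. Each step has a limit at one end and so gives only a minimum size: the limit of > 10000 nM in this assay, at which 2 of the 3 values shown sit.

On these data alone, whether methylamino, diethylamino or a pyrrolidine ring would be tolerated here remains open. So does whether the chlorine and methoxy groups of the shared core contribute to the value of compound 3.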